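Changing the Amine Arm: Benzodioxinyl to Chlorophenyl

The source may hold more compounds than are shown below. What is called first, only, known or untested is meant among the compounds shown, and "the series" means these compounds.

Three sulfonamides sharing one core have been measured in a functional assay on A2780 cells (Homo sapiens) for inhibition, read by MTT assay, with a stated time of 72 h; on this read-out lower numbers stand for stronger inhibition of growth and higher numbers for weaker inhibition of growth. Compound 1 `O=S(=O)(NCCNCc1cccc2ccccc12)c1cc(C(F)(F)F)cc(C(F)(F)F)c1` gives 21000 nM. Compound 2 `COc1ccc(CNCCCNS(=O)(=O)c2cc(C(F)(F)F)cc(C(F)(F)F)c2)cc1OC` gives 3800 nM, and compound 3 `O=S(=O)(NCCCNCC1COc2ccccc2O1)c1cc(C(F)(F)F)cc(C(F)(F)F)c1` gives 1500 nM, the lowest of the three numbers and so the strongest inhibition of growth seen so far. The step of a 2.5-fold lower number from compound 2 to compound 3 (0.40 log units; beyond the scatter) separates the two closest compounds, while the gap from compound 1 to compound 3 is wider still. Compound 1 also has a shorter chain, so its value reflects two differences at once rather than the arm alone.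

Compound 4 `O=S(=O)(NCCCNCc1ccc(Cl)cc1)c1cc(C(F)(F)F)cc(C(F)(F)F)c1` has not yet been measured. Compared with compound 3 it carries 4-chlorophenyl in place of 2,3-dihydro-1,4-benzodioxin-2-yl on a saturated chain carbon bound to an amine nitrogen. Among the compounds with values here, the one measured step that speaks to the arm on the saturated chain carbon is a 2.5-fold lower number from compound 2 to compound 3 (0.40 log units; beyond the scatter), which shows that exchanging one arm for another moves the number by a modest amount. Within the data shown here, no measured compound carries the 4-chlorophenyl arm, so direction is uncertain; a drift back toward the number of compound 2, or no change beyond the scatter, both look plausible. The expected step is a 2.0-fold higher number from compound 3 to compound 4 (0.30 log units; within the scatter). Compound 4 is therefore estimated at 3000 nM, with a range from 1000 nM to 9000 nM.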

Compound 4, concentration for 50% growth inhibition: 1800 nM
Estimate against measurement, compound 4: 1.7-fold (0.22 log units) above; measured number inside the range.
By their numbers in this assay, from the lowest: compounds 3 and 4 (each within the scatter of the next); then compound 2; then compound 1.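

In this assay, the arm on a saturated chain carbon bound to an amine nitrogen can change from a fused two-ring group to a single aromatic ring with a 1.2-fold higher number from compound 3 to compound 4 (0.08 log units; within the scatter), even though 4-chlorophenyl has 0 hydrogen-bond acceptors where 2,3-dihydro-1,4-benzodioxin-2-yl has 2, so neither that second ring nor those acceptors is needed to hold the number at this level in this pair. The earlier compounds shown here also left it possible that a single aromatic ring at this position would stay at the level of compound 2, but exchanging 3,4-dimethoxyphenyl for 4-chlorophenyl gives a 2.1-fold lower number from compound 2 to compound 4 (0.32 log units; beyond the scatter), which shows that the groups carried on the phenyl ring can shift the number by a modest amount. No measurement here explains either step, and the reason for them remains unknown.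

A plain phenyl arm or a 4-fluorophenyl arm would show whether the chlorine itself contributes to the number of compound 4. The 4-chlorophenyl arm on a shorter or a longer chain would show how far this result depends on the chain of compound 4.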